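The compounds below may be only part of what the source reports. "The series", "measured", "known", "first", "only" and "open" are said of these compounds alone.

In a functional assay on MGC-803 cells (Homo sapiens) for cytotoxicity, read by MTT assay, with a stated time of 72 h (on this read-out lower numbers stand for stronger inhibition and higher numbers for weaker inhibition), compound 1 `O=C1C(=Cc2ccc(Cl)cc2)C(=O)N(c2ccc(Cl)cc2)N1c1ccc(Cl)cc1` gives 32600 nM and compound 2 `COc1cc(C=C2C(=O)N(c3ccc(Cl)cc3)N(c3ccc(Cl)cc3)C2=O)ccc1O` gives 21800 nM on the same core, and the gap between them is a 1.5-fold lower number from compound 1 to compound 2 (0.17 log units; within the scatter) only. Compound 3 `O=C1C(=Cc2ccc(Cl)cc2Cl)C(=O)N(c2ccc(Cl)cc2)N1c1ccc(Cl)cc1` returns no number, only the limit > 128000 nM as its reading. The steps to it, an at least 3.9-fold higher number from compound 1 to compound 3 (0.59 log units; beyond the scatter) and an at least 5.8-fold higher number from compound 2 to compound 3 (0.76 log units; beyond the scatter), are both beyond the scatter. Compound 4 `O=C1C(=Cc2ccco2)C(=O)N(c2ccc(Cl)cc2)N1c1ccc(Cl)cc1` has furan-2-yl in place of 2,4-dichlorophenyl on a double-bonded chain carbon bound to a double-bonded ring carbon. Among the compounds with values here, compound 1 and compound 2 carry different groups at this place yet stay close, so a return towards them is expected, though no measured compound carries furan-2-yl. The expected change is an at least 4.0-fold lower number from compound 3 to compound 4 (0.60 log units; beyond the scatter) as an estimate, towards a lower number. Compound 4 is estimated at 32000 nM within a range of 11000 nM to 95000 nM in this assay.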

Compound 4, half-maximal inhibitory concentration: 12800 nM
Compound 4: the middle estimate sits 2.5-fold (0.40 log units) above what was measured; measured number inside the range.
By their numbers in this assay, from the lowest: compounds 4, 2 and 1 (each within the scatter of the next, the first and the last beyond it). At a limit, above all of these: compound 3.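

On a double-bonded chain carbon bound to a double-bonded ring carbon, a phenyl ring is not needed to keep a measurable number. Furan-2-yl, a five-membered aromatic ring, gives a 2.5-fold lower number from compound 1 to compound 4 (0.41 log units; beyond the scatter), a modest gain, and a 1.7-fold lower number from compound 2 to compound 4 (0.23 log units; within the scatter), which is no real difference. As far as these compounds go, the remaining step, an at least 10-fold lower number from compound 3 to compound 4 (1.00 log units; beyond the scatter), starts from a limit and not a number, and its true size is unknown: the limit of > 128000 nM in this assay, at which 1 of the 4 values shown sits.

Furan-2-yl is the only five-membered ring shown here. From the compounds shown here alone, how thiophen-2-yl, or a phenyl ring carrying an amine or a carboxylic acid, would read at this place remains open.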